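A few compounds are considered here, and "the series" means these few. Any claim that something is new, unique, unknown or untested is made for them only; others in the source may bear on it.

- compound 1 `CNC(=O)/C=C/CN1CC(Oc2ccc(Oc3c(-c4ccc(F)cc4)sc4cc(O)ccc34)cc2)C1`: > 25000 nM
- compound 2 `CN(C)C(=O)/C=C/CNCCOc1ccc(Oc2c(-c3ccc(F)cc3)sc3cc(O)ccc23)cc1`: 13800 nM

Within the data shown here, in a functional assay on MCF7 cells (Homo sapiens) for antiproliferative activity, read by CCK-8 assay, with a stated time of 48 h (on this read-out higher numbers stand for weaker inhibition and lower numbers for stronger inhibition), compound 2 gives 13800 nM, the only true number so far. Compound 1 gives > 25000 nM, which is a limit of the assay and not a number. Compound 3 `O=C(/C=C/CNCCOc1ccc(Oc2c(-c3ccc(F)cc3)sc3cc(O)ccc23)cc1)N1CCC1` differs from compound 2 in one place: azetidin-1-yl in place of dimethylamino on a carbonyl carbon. Among the measured compounds shown here, the only measured step, an at least 1.8-fold lower number from compound 1 to compound 2 (0.25 log units; that floor lies within the scatter), changes more than this one group, so it gives no clean size for the swap. No step beyond the scatter is therefore expected in this assay. Compound 3 is expected at 14000 nM, with an estimated range of 6500 nM to 25000 nM. This estimate means a 1.0-fold higher number from compound 2 to compound 3 (0.01 log units; within the scatter).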

Compound 3, half-maximal inhibitory concentration: 7340 nM
The estimate for compound 3 lay 1.9-fold (0.28 log units) above the measured number; measured number inside the range.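

In this assay, azetidin-1-yl on the carbonyl carbon gives a 1.9-fold lower number from compound 2 to compound 3 (0.27 log units; within the scatter), so this position accepts a four-membered ring in place of dimethylamino with no shift that stands out from the scatter. Among these compounds, the wider step, an at least 3.4-fold lower number from compound 1 to compound 3 (0.53 log units; beyond the scatter), is the first to pass the scatter, yet it changes more than one group. Its size is only a floor, set by compound 1, whose value is a limit of the assay and not a number: the limit of > 25000 nM in this assay, at which 1 of the 3 values shown sits.

From the compounds shown here alone, whether a larger ring on the carbonyl carbon, such as piperidin-1-yl or morpholin-4-yl, would move the number stays open. So does which of the groups changed in the wider step carries that step.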